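This account rests on a few compounds, and the source may have more. Where it says the series, first, only, none or still open, it means among the compounds named here.

Measured so far in a functional assay on CHO-K1 cells for antagonist activity at adenosine receptor A1 (Homo sapiens), read by a beta-galactosidase reporter and cAMP accumulation, with stated times of 15 min and 6 h; a lower number here means a stronger inhibitor, a higher number a weaker inhibitor:
compound 1 `Nc1nc(-c2ccc(C3CC3)o2)nc2sc(Cc3ccccc3)cc12` gives 861 nM;
compound 2 `Nc1nc(C2CCCO2)nc2sc(Cc3ccccc3)cc12` gives 2950 nM.

Within the data shown here, compound 2 has the highest of the two numbers, so it is the weaker inhibitor of the pair; the only step to it, a 3.4-fold higher number from compound 1 to compound 2 (0.53 log units; beyond the scatter), came from exchanging a five-membered aromatic ring for the saturated oxolan-2-yl. Compound 3 `Cn1cnc(-c2nc(N)c3cc(Cc4ccccc4)sc3n2)c1` reverses that kind of exchange: 1-methyl-1H-imidazol-4-yl in place of oxolan-2-yl on an aromatic carbon. Among the measured compounds shown here, no measured step covers exactly this new ring, so the single step from compound 1 to compound 2 is the only guide. Because that step is a 3.4-fold higher number from compound 1 to compound 2 (0.53 log units; beyond the scatter), returning to a five-membered aromatic ring at the same place is expected to move this assay back down by a comparable, modest amount. Compound 3 is therefore estimated at 1200 nM, with a range of 400 nM to 3500 nM, the expected step being a 2.5-fold lower number from compound 2 to compound 3 (0.39 log units; beyond the scatter).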

Compound 3, inhibition constant: 2330 nM
The estimate for compound 3 lay 1.9-fold (0.29 log units) below the measured number, and the stated range covers the measured number.
By their numbers in this assay, from the lowest: compound 1; then compounds 3 and 2 (each within the scatter of the next).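

In this assay, an aromatic ring at this place does not by itself bring the number back towards that of compound 1: exchanging oxolan-2-yl for 1-methyl-1H-imidazol-4-yl leaves only a difference within the scatter (a 1.3-fold lower number from compound 2 to compound 3 (0.10 log units; within the scatter)). The 5-cyclopropylfuran-2-yl group therefore stands apart from both other groups, not just the saturated one (a 2.7-fold higher number from compound 1 to compound 3 (0.43 log units; beyond the scatter)), so the aromatic or saturated nature of the ring does not separate these three compounds on its own. The data offer no explanation for these numbers.

The compounds shown leave open whether the advantage of compound 1 belongs to the furan ring, to its cyclopropyl group, or to the two together. A plain furan-2-yl, or a phenyl ring, at the same place would help to separate these possibilities.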